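The source may report more compounds than this note shows. Statements on the series, on what has been measured and on what is new or still open speak of the compounds shown alone.

Three measured compounds: compound 1 `O=c1c2c(Nc3ccccc3)nn(-c3ccc([N+](=O)[O-])cc3)c2nc(Nc2ccccc2)n1-c1ccccc1`, compound 2 `NS(=O)(=O)c1ccc(-n2nc(Nc3ccccc3)c3c(=O)n(-c4ccccc4)c(Nc4ccccc4)nc32)cc1`, and compound 3 `Cc1ccc(Nc2nn(-c3ccc([N+](=O)[O-])cc3)c3nc(Nc4ccccc4)n(-c4ccccc4)c(=O)c23)cc1`. In a functional assay on the whole organism (strain Wistar albino) for inhibition, with Rattus norvegicus as the target, read by paw edema, with a stated time of 3 h, at a dose of 25 mg/kg by the oral route (a higher number here means more inhibition at the dose given (going by the name of the read-out), a lower number less inhibition), compound 1 gives 14.1%, compound 2 gives 39.7%, and compound 3 gives 30.2%.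

Compound 2 differs from compound 1 by sulfamoyl in place of nitro on an aromatic carbon, a change that brought a number 25.6 percentage points higher from compound 1 to compound 2 (beyond the scatter). The core of compound 3 differs from the core of compound 1 by methyl in place of hydrogen on an aromatic carbon, which brought a number 16.1 percentage points higher from compound 1 to compound 3 (beyond the scatter). The values of compound 2 and compound 3 lie within the scatter of each other.

Compound 4 `Cc1ccc(Nc2nn(-c3ccc(S(N)(=O)=O)cc3)c3nc(Nc4ccccc4)n(-c4ccccc4)c(=O)c23)cc1` has not yet been measured. It differs from compound 3 by sulfamoyl in place of nitro on an aromatic carbon, the same change, at the same place, as that from compound 1 to compound 2. For compound 4 a step of a number 21.8 percentage points higher from compound 3 to compound 4 (beyond the scatter) is expected in this assay, beside the earlier a number 25.6 percentage points higher from compound 1 to compound 2 (beyond the scatter), because compound 3 already stands at 30.2% and the change carries the same group into the same place. Compound 4 is therefore estimated at 52%, between 38% and 66%.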

Compound 4, a percentage reported as inhibition, in the whole organism at one dose (the size of the read-out at that dose, not a potency): 43.7%
For compound 4 the middle estimate is 8.3 percentage points above the measured one, and the stated range covers the measured number.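

In this assay, sulfamoyl in place of nitro on an aromatic carbon again gave a higher number, a number 13.5 percentage points higher from compound 3 to compound 4 (beyond the scatter), and the two steps for this change do not differ: the same change on two cores in this assay, a number 25.6 percentage points higher (beyond the scatter) from compound 1 to compound 2 and a number 13.5 percentage points higher (beyond the scatter) from compound 3 to compound 4, 12.1 percentage points apart, within the scatter of two such steps. Methyl in place of hydrogen gave a number 4 percentage points higher from compound 2 to compound 4 (within the scatter), and this step likewise cannot be set apart from the earlier one: the same change on two cores in this assay, a number 16.1 percentage points higher (beyond the scatter) from compound 1 to compound 3 and a number 4 percentage points higher (within the scatter) from compound 2 to compound 4, 12.1 percentage points apart, within the scatter of two such steps. Both changes thus carried over between cores within the scatter, but two pairs per change do not show that this holds on any other core, nor do they explain the result.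

The compounds shown leave open whether a carboxylic acid or an amine in the place of the sulfamoyl would give a similar number. They also leave open whether a methoxy group or a chlorine in place of the methyl would do so.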